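Swapping a benzyloxy arm for a butylsulfanyl chain

The source may hold more compounds than are shown below. What is called first, only, known or untested is meant among the compounds shown, and "the series" means these compounds.

Compound 1 `CC(C(=O)NCc1ccc(C(C)(C)C)nc1OCc1ccc(F)cc1)c1ccc(NS(C)(=O)=O)c(F)c1` is the reference here. In an assay on cells for antagonist activity at transient receptor potential cation channel subfamily V member 1 (Homo sapiens), read by FLIPR and calcium flux, with a stated time of 6 min (on this read-out higher numbers stand for weaker inhibition and lower numbers for stronger inhibition), compound 1 gives 0.8 nM. Compound 2 `CCCCSc1nc(C(C)(C)C)ccc1CNC(=O)C(C)c1ccc(NS(C)(=O)=O)c(F)c1` differs from it by butylsulfanyl in place of (4-fluorobenzyl)oxy on an aromatic carbon, and in this assay compound 2 gives 3.2 nM, a step of a 4.0-fold higher number from compound 1 to compound 2 (0.60 log units; beyond the scatter). Compound 3 `CC(C(=O)NCc1ccc(C(C)(C)C)cc1OCc1ccc(F)cc1)c1ccc(NS(C)(=O)=O)c(F)c1` carries a different core; the difference between the two cores is not broken down here. In this assay compound 3 gives 3.8 nM. Compound 4 `CCCCSc1cc(C(C)(C)C)ccc1CNC(=O)C(C)c1ccc(NS(C)(=O)=O)c(F)c1`, not yet measured, differs from compound 3 by butylsulfanyl in place of (4-fluorobenzyl)oxy on an aromatic carbon. This is the same kind of change as that from compound 1 to compound 2, though in compound 1 the place lies on a six-membered aromatic ring with 1 nitrogen, next to the ring nitrogen, while in compound 3 it lies on a ring of carbon only. A step of a 3.2-fold higher number from compound 3 to compound 4 (0.50 log units; beyond the scatter) is expected, resting on the step seen in a 4.0-fold higher number from compound 1 to compound 2 (0.60 log units; beyond the scatter). Compound 4 is therefore estimated at 12 nM, between 4 nM and 40 nM.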

Compound 4, inhibition constant: 6.7 nM
Estimate against measurement, compound 4: 1.8-fold (0.25 log units) above, within the range that was stated.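

In this assay butylsulfanyl in place of (4-fluorobenzyl)oxy gives a 1.8-fold higher number from compound 3 to compound 4 (0.25 log units; within the scatter) on this core. Set beside the same change on the core of compound 1, the two steps do not differ by more than the scatter allows: the same change on two cores in this assay, a 4.0-fold higher number (0.60 log units; beyond the scatter) from compound 1 to compound 2 and a 1.8-fold higher number (0.25 log units; within the scatter) from compound 3 to compound 4, 2.3-fold (0.36 log units) apart, within the scatter of two such steps. So the change carries across these two cores about equally as far as can be judged, but two pairs make no rule, and they do not show why the numbers shift or whether the step truly differs in size between the cores.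

The compounds shown leave open how other groups would behave at this place, such as an amine or a longer chain like hexylsulfanyl. They also leave open whether the change would carry to any further core.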